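Swapping a naphthyl for a fluorophenyl on a shared core

The compounds below may be only part of what the source reports. "The series", "measured", "known", "first", "only" and "open" are said of these compounds alone.

Compounds measured so far:
compound 1, `Brc1cn2ccnc2c(-c2ccc3ncn(C4CCCCC4)c3c2)n1`, 9.15%
compound 2, `COc1ccc(-c2cn3ccnc3c(-c3ccc4ncn(C5CCCCC5)c4c3)n2)cc1`, 46.4%
compound 3, `c1ccc2c(-c3cn4ccnc4c(-c4ccc5ncn(C6CCCCC6)c5c4)n3)cccc2c1`, 19.7%

In a functional assay on OVCAR-4 cells (Homo sapiens) for inhibition, read by sulforhodamine B assay, with a stated time of 48 h, tested at 10 uM (on this read-out lower numbers stand for less inhibition and higher numbers for more inhibition at the one concentration tested (going by the name of the read-out)), compound 3 stands second highest of the three. Its nearest neighbour is compound 1, reached by a number 10.6 percentage points higher from compound 1 to compound 3 (beyond the scatter), and its furthest is compound 2, reached by a number 26.7 percentage points lower from compound 2 to compound 3 (beyond the scatter). Compound 4, `Fc1ccc(-c2cn3ccnc3c(-c3ccc4ncn(C5CCCCC5)c4c3)n2)cc1`, has not yet been measured. It differs from compound 3 in one place: 4-fluorophenyl in place of naphthalen-1-yl on an aromatic carbon. Among the compounds with values here, the steps that bear on this are the two that replaced the bromo group with an aromatic group, a number 37.3 percentage points higher from compound 1 to compound 2 (beyond the scatter) and a number 10.6 percentage points higher from compound 1 to compound 3 (beyond the scatter), together with a number 26.7 percentage points lower from compound 2 to compound 3 (beyond the scatter). A single six-membered carbon ring carrying a small group gave the higher number in compound 2, and a two-ring group gave the lower one in compound 3, so the change to compound 4 is expected to raise the inhibition, by a step of modest size, a number 15.3 percentage points higher from compound 3 to compound 4 (beyond the scatter). For compound 4 the estimate in this assay is 35%, expected to fall between 12% and 58%.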

Compound 4, a percentage reported as inhibition, at one concentration (the size of the read-out at that concentration, not a potency): 5.73%
Compound 4: the middle estimate sits 29.3 percentage points above what was measured; the measured number lies below the stated range.
By their numbers in this assay, from the lowest: compounds 4 and 1 (each within the scatter of the next); then compound 3; then compound 2.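

In this assay, a single aromatic ring at this position does not raise the number by itself: 4-fluorophenyl in place of bromo gives a number 3.4 percentage points lower from compound 1 to compound 4 (within the scatter). What the ring carries matters a great deal, as fluoro in place of methoxy gives a number 40.7 percentage points lower from compound 2 to compound 4 (beyond the scatter), so the higher number of compound 2 cannot be credited to the six-membered ring alone, and 4-fluorophenyl in place of naphthalen-1-yl gives a number 14 percentage points lower from compound 3 to compound 4 (beyond the scatter), so one ring does not always beat two. No measurement here explains why these groups differ.

The compounds shown leave open whether methoxy is unusual among groups on this ring or one of several that lift the number. A hydroxy, an ethoxy or a dimethylamino group in place of the fluoro would help separate those two readings.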